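Capping the chain amine of compound 2 with tert-butoxycarbonyl

The source may hold more compounds than are shown below. What is called first, only, known or untested is meant among the compounds shown, and "the series" means these compounds.

Of the compounds shown here, two from this series carry numbers so far. Compound 1 `CCN1C(N2CCCCC2)=Nc2ccccc2C1CC(=O)NCc1ccccc1` gives 4580 nM in an assay on HEK293 cells for inhibition of Voltage-dependent T-type calcium channel subunit alpha-1G (Homo sapiens); on this read-out higher numbers stand for weaker inhibition and lower numbers for stronger inhibition. Compound 2 `COC(=O)CC1c2ccccc2N=C(Nc2ccccc2)N1CCCCCN` gives 9160 nM in this assay, and the two values sit within the scatter of each other, so neither compound can be set apart from the other on this read-out.

Compound 3 `COC(=O)CC1c2ccccc2N=C(Nc2ccccc2)N1CCCCCNC(=O)OC(C)(C)C` has not yet been measured. It differs from compound 2 in one place: tert-butoxycarbonyl in place of hydrogen on an amine nitrogen. Within the data shown here, no measured pair in this set shows what such a change does, and compound 1 shares neither the ester nor the free amine chain with compound 2, so its value offers no guide to the size of the step.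

With nothing shown for the change itself, the account expects a step from compound 2 to compound 3 of about a 1.3-fold lower number from compound 2 to compound 3 (0.12 log units; within the scatter), which is to say no step beyond the scatter. On that basis compound 3 is estimated at 7000 nM in this assay, with a range from 2000 nM to 25000 nM.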

Compound 3, half-maximal inhibitory concentration: 2270 nM
Estimate against measurement, compound 3: 3.1-fold (0.49 log units) above, within the range that was stated.
By their numbers in this assay, from the lowest: compounds 3, 1 and 2 (each within the scatter of the next, the first and the last beyond it).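

Capping the chain amine with tert-butoxycarbonyl gives a 4.0-fold lower number from compound 2 to compound 3 (0.61 log units; beyond the scatter) in this assay, the only step in this set that lies beyond the scatter between compounds differing in one place. It shows that the terminal nitrogen of the pentyl chain tolerates substitution: with its free amine replaced by a carbamate, compound 3 does not lose inhibition and instead gives the lower number of the pair. The data given here contain nothing that bears on why the number falls with this change.

Among these compounds, the single pair leaves open which part of the tert-butoxycarbonyl group goes with the step, since it cannot be said whether an acetyl or methoxycarbonyl group on the same nitrogen, or a simple methyl group, would give a similar number, or whether a shorter or longer chain carrying the same cap would hold it. It also leaves open whether the cap would act in the same way with a carboxylic acid or an amide in place of the methyl ester, or with a group other than the anilino substituent on the shared core.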